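Aryl swap on the ring nitrogen of compound 2

This account rests on a few compounds, and the source may have more. Where it says the series, first, only, none or still open, it means among the compounds named here.

Measured so far, in a functional assay on the whole organism for inhibition, with Mus musculus as the target, at a dose of 25 mg/kg by the oral route; on this read-out higher numbers stand for more inhibition at the one dose given (going by the name of the read-out) and lower numbers for less inhibition:
compound 1 `Clc1cc(Cl)cc(N2CCN(CCCOc3ccc4c(c3)CCC4)CC2)c1` gives 0%;
compound 2 `COc1ccccc1N1CCN(CCCOc2ccc3c(c2)CCC3)CC1` gives 19%;
compound 3 `COc1ccccc1N1CCN(CCCCOc2ccc3c(c2)CCC3)CC1` gives 42%.

Compound 2 stands second of the three numbers in this assay, with compound 1 lower by a step beyond the scatter and compound 3 higher by a step beyond the scatter. For the measured compounds named here, the only change of the aryl group on the ring nitrogen that has been measured is a number 19 percentage points higher from compound 1 to compound 2 (beyond the scatter), a modest rise.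

Compound 4 `O=[N+]([O-])c1ccc(N2CCN(CCCOc3ccc4c(c3)CCC4)CC2)cc1` differs from compound 2 by 4-nitrophenyl in place of 2-methoxyphenyl on an amine nitrogen in a ring. The step from compound 1 to compound 2 shows that exchanging this aryl group can move the number by a modest amount in this assay, but 4-nitrophenyl has not been tried, so the direction for compound 4 is open. The expected step is a number 4 percentage points lower from compound 2 to compound 4 (within the scatter), not beyond the scatter. For compound 4 the estimate in this assay is 15%, with a range from 0% to 40%.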

Compound 4, a percentage reported as inhibition, in the whole organism at one dose (the size of the read-out at that dose, not a potency): 26%
For compound 4 the middle estimate is 11 percentage points below the measured one, and the stated range covers the measured number.
By their numbers in this assay, from the lowest: compound 1; then compounds 2 and 4 (each within the scatter of the next); then compound 3.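

In this assay, 4-nitrophenyl in place of 2-methoxyphenyl on the amine nitrogen in the ring gives a number 7 percentage points higher from compound 2 to compound 4 (within the scatter), so this exchange of aryl groups does not separate the two compounds. Against 3,5-dichlorophenyl, the same group gives a number 26 percentage points higher from compound 1 to compound 4 (beyond the scatter), so among these three aryl groups on the same chain, compound 1 now stands apart from both compound 2 and compound 4 by steps beyond the scatter. Nothing at hand offers an explanation for these differences among the aryl groups.

Open, from the compounds shown here alone, is how 4-nitrophenyl would read on the longer chain of compound 3, which gives 42% in this assay. Also open, going by these compounds, is whether a plain phenyl or a 4-aminophenyl group on the same ring nitrogen would stay with compound 2 and compound 4 or fall towards compound 1.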